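Halogen swap on the benzoyl ring: chloro to iodo

The source may hold more compounds than are shown below. What is called first, only, known or untested is meant among the compounds shown, and "the series" means these compounds.

Compound 1 `CC(/C=N/Nc1ccc([N+](=O)[O-])cc1)=N\NC(=O)c1ccccc1Cl` is the anchor of this set. In an ADME assay on J774 cells (Mus musculus, strain BALB/c) for cytotoxicity, read by resazurin assay, with a stated time of 72 h (on this read-out higher numbers stand for lower toxicity in this test and lower numbers for higher toxicity in this test), compound 1 gives only a limit of the assay, > 100000 nM, and no number. Compound 2 `CC(/C=N/Nc1ccc([N+](=O)[O-])cc1)=N\NC(=O)c1ccccc1` removes the chloro, and in this assay compound 2 likewise stops at the limit > 100000 nM. Compound 3 `CC(/C=N/Nc1ccc([N+](=O)[O-])cc1)=N\NC(=O)c1ccc([N+](=O)[O-])cc1` carries a 4-nitrophenyl on the carbonyl carbon, and in this assay compound 3 also reaches only the limit > 100000 nM. The step from compound 1 to compound 2, a step that the two limits leave unreadable from compound 1 to compound 2, the step from compound 1 to compound 3, a step that the two limits leave unreadable from compound 1 to compound 3, and the step from compound 2 to compound 3, a step that the two limits leave unreadable from compound 2 to compound 3, therefore give no size that can be read, because of the limit of > 100000 nM in this assay, at which 3 of the 3 values shown sit.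

Compound 4 `CC(/C=N/Nc1ccc([N+](=O)[O-])cc1)=N\NC(=O)c1ccccc1I` is the next member, with the difference iodo in place of chloro on an aromatic carbon from compound 1. For the measured compounds named here, no measured step on this core resolves a change of this kind, and every value so far is a limit, so the expectation rests on the whole set sitting at the limit. The step from compound 1 to compound 4 is estimated as a step that the limit leaves unreadable from compound 1 to compound 4, with compound 4 expected to stay above the readable range. For compound 4 the estimate in this assay is 150000 nM, with a range from 60000 nM to 400000 nM.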

Compound 4, half-maximal cytotoxic concentration: 40000 nM
For compound 4 the middle estimate is 3.8-fold (0.57 log units) above the measured one; measured number outside the range, below it.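

For the compounds shown here, compound 4 is the first member of the set to give a readable number in this assay, so the substituent on this aromatic carbon, ortho to a large group, can move the read-out towards higher toxicity in this test. Iodo in place of chloro gives an at least 2.5-fold lower number from compound 1 to compound 4 (0.39 log units; beyond the scatter), iodo in place of hydrogen gives an at least 2.5-fold lower number from compound 2 to compound 4 (0.39 log units; beyond the scatter), and 2-iodophenyl in place of 4-nitrophenyl on the carbonyl carbon gives an at least 2.5-fold lower number from compound 3 to compound 4 (0.39 log units; beyond the scatter). These three sizes are floors, and the steps among compound 1, compound 2 and compound 3 still cannot be read, because of how the values fall: the limit of > 100000 nM in this assay, at which 3 of the 4 values shown sit.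

The compounds shown leave open whether the readable number belongs to iodo alone, since bromo on the same aromatic carbon would show whether compound 4 marks a trend across the halogens or a single case. Also open, going by these compounds, is whether a methoxy group or an amine at this place would keep the number near that of compound 4, and how far the true values of the other three compounds lie from it.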